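The source may hold more compounds than are shown below. What is called first, only, known or untested is meant among the compounds shown, and "the series" means these compounds.

Compound 1 `c1cnc2c(c1)CCC[C@@H]2N(CC1CC1)C[C@H]1Cc2c(cccc2N2CCNCC2)CN1` was tested in an ADME assay on microsomes from liver (Homo sapiens) for metabolic stability, read by LC-MS, with a stated time of 10 min (a higher number here means that more of the compound is left, a lower number that less of the compound is left), where compound 1 gives 82.1%. Among the three compounds measured it stands second highest: compound 2 `CN(C[C@H]1Cc2c(cccc2N2C[C@@H]3C[C@H]2CN3)CN1)[C@H]1CCCc2cccnc21` gives 100%, and compound 3 `CC(C)N1CCN(c2cccc3c2C[C@H](CN(C)[C@H]2CCCc4cccnc42)NC3)CC1` gives 56.6%. For the measured compounds named here, the only measured step, a number 43.4 percentage points lower from compound 2 to compound 3 (beyond the scatter), concerns a change on an aromatic carbon and does not bear on the change studied here. Compound 4 `CCN(C[C@H]1Cc2c(cccc2N2CCNCC2)CN1)[C@H]1CCCc2cccnc21` differs from compound 1 in one place: methyl in place of cyclopropyl on a saturated chain carbon bound to an amine nitrogen. Going by the values given here, no measured step touches this position; no change beyond the scatter is expected from such a small change. Compound 4 is expected to give 78%, in a range from 60% to 95%. The expected step of a number 4.1 percentage points lower from compound 1 to compound 4 (within the scatter) is accordingly small.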

Compound 4, percent of the compound remaining: 79.1%
Compound 4: the middle estimate sits 1.1 percentage points below what was measured, and the stated range covers the measured number.
By their numbers in this assay, from the lowest: compound 3; then compounds 4 and 1 (each within the scatter of the next); then compound 2.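

This position was not touched by any earlier step. In this assay, methyl in place of cyclopropyl gives a number 3 percentage points lower from compound 1 to compound 4 (within the scatter), so on this saturated chain carbon the three-membered ring can be removed without a change beyond the scatter. Nothing available explains why the two compounds read alike.

Going by these compounds, whether this holds for a longer chain or a chain carrying a hydroxyl group remains open. So does whether the same change would read alike with the aromatic-carbon group of compound 3 in place.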